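An Ethyl Group Takes the Place of Bromine

The source may hold more compounds than are shown below. What is called first, only, known or untested is meant among the compounds shown, and "the series" means these compounds.

Measured compounds:
compound 1, `Cc1ccccc1N/C(=N\C#N)Nc1ccc(Cl)c(S(=O)(=O)N(C)C)c1O`, 378 nM
compound 2, `CN(C)S(=O)(=O)c1c(Cl)ccc(N/C(=N/C#N)Nc2ccccc2F)c1O`, 1550 nM
compound 3, `CN(C)S(=O)(=O)c1c(Cl)ccc(N/C(=N/C#N)Nc2ccccc2Br)c1O`, 55 nM

Of the three compounds measured in an assay on CHO cells for displacement of a labelled ligand from C-X-C chemokine receptor type 1 (Homo sapiens) (a higher number here means a weaker inhibitor, a lower number a stronger inhibitor), compound 3 gives the lowest number, and both of its steps to the others lie beyond the scatter: a 6.9-fold lower number from compound 1 to compound 3 (0.84 log units; beyond the scatter) and a 28-fold lower number from compound 2 to compound 3 (1.45 log units; beyond the scatter). Compound 4, `CCc1ccccc1N/C(=N\C#N)Nc1ccc(Cl)c(S(=O)(=O)N(C)C)c1O`, is not yet measured. It differs from compound 3 in one place: ethyl in place of bromo on an aromatic carbon. The step that bears most directly on this change is a 6.9-fold lower number from compound 1 to compound 3 (0.84 log units; beyond the scatter), as methyl and ethyl are both alkyl chains; a reversal of that gain is therefore expected, a modest rise in the number in this assay, a 3.6-fold higher number from compound 3 to compound 4 (0.56 log units; beyond the scatter). For compound 4 the estimate is 200 nM, within the range 50 nM to 800 nM.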

Compound 4, half-maximal inhibitory concentration: 512 nM
Estimate against measurement, compound 4: 2.6-fold (0.41 log units) below; low and high end bracket the measured number.
By their numbers in this assay, from the lowest: compound 3; then compounds 1 and 4 (each within the scatter of the next); then compound 2.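

Ethyl does not hold the gain that bromo gives at this position on the aromatic ring, with a 9.3-fold higher number from compound 3 to compound 4 (0.97 log units; beyond the scatter) marking a clear loss. Extending the alkyl group from methyl to ethyl changes nothing that can be read, with a 1.4-fold higher number from compound 1 to compound 4 (0.13 log units; within the scatter) in the place of a real difference. Ethyl still keeps an advantage over fluoro, with a 3.0-fold lower number from compound 2 to compound 4 (0.48 log units; beyond the scatter) on that side, so bromo alone stands apart from the alkyl pair.

Nothing measured here explains the gap between bromo and ethyl. On these data alone, whether chloro, methoxy or a longer chain such as propyl would follow bromo or the alkyl pair remains open.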